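The compounds below may be only part of what the source reports. "The series", "measured", "known", "first", "only" and "open" are said of these compounds alone.

Of the compounds shown here, three built on one shared core have been tested in a functional assay on MCF7 cells (Homo sapiens) for antiproliferative activity, read by MTT assay, with a stated time of 24 h; a higher number here means a weaker inhibitor, a lower number a stronger inhibitor. Compound 1 `CCn1c(C(=O)NCCO)ccc1C(CC)(CC)c1ccc(OCS(=O)(=O)c2ccccc2)c(C)c1` gives 15500 nM, the lowest of the three numbers, though its neighbours sit within the usual scatter of it. Compound 2 `CCn1c(C(=O)NC2(CO)CC2)ccc1C(CC)(CC)c1ccc(OCS(=O)(=O)c2ccccc2)c(C)c1` gives 28800 nM, and compound 3 `CCn1c(C(=O)N[C@H](C(=O)O)C(C)C)ccc1C(CC)(CC)c1ccc(OCS(=O)(=O)c2ccccc2)c(C)c1` gives 24500 nM. The step of a 1.9-fold higher number from compound 1 to compound 2 (0.27 log units; within the scatter) and the step of a 1.6-fold higher number from compound 1 to compound 3 (0.20 log units; within the scatter) both stay within the scatter, as does the step of a 1.2-fold lower number from compound 2 to compound 3 (0.07 log units; within the scatter).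

Compound 4 `CCn1c(C(=O)NCCC(=O)O)ccc1C(CC)(CC)c1ccc(OCS(=O)(=O)c2ccccc2)c(C)c1` is not yet measured. It differs from compound 1 as follows: carboxy in place of hydroxy on a saturated chain carbon, two bonds along the chain from an amide-type nitrogen. Because the step of a 1.6-fold higher number from compound 1 to compound 3 (0.20 log units; within the scatter) also brought a carboxy group onto the amide-type nitrogen side chain without moving beyond the scatter, no step beyond the scatter is expected here, that is an expected 1.2-fold higher number from compound 1 to compound 4 (0.06 log units; within the scatter). The estimate for compound 4 in this assay is 18000 nM, with a range from 8000 nM to 40000 nM.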

Compound 4, half-maximal inhibitory concentration: > 50000 nM
Compound 4: only a limit was reported (the forecaster's own chance of this, stated with the estimate: 10%); middle value at least 2.7-fold (0.44 log units) from the limit.
By their numbers in this assay, from the lowest: compounds 1, 3 and 2 (each within the scatter of the next). At a limit, above all of these: compound 4.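

Compound 4 gives > 50000 nM in this assay and that is a limit of the assay, not a number. Carboxy in place of hydroxy on this saturated chain carbon gives an at least 3.2-fold higher number from compound 1 to compound 4 (0.50 log units; beyond the scatter) and is the first step here to pass the scatter, so this end of the side chain does respond to change. Only floors stand in an at least 2.0-fold higher number from compound 3 to compound 4 (0.30 log units; that floor lies within the scatter) and in an at least 1.7-fold higher number from compound 2 to compound 4 (0.23 log units; that floor lies within the scatter) and these fix no order among those side chains.

On these data alone, how an amine or a methyl ester at the same chain end would compare with hydroxy and carboxy stays open.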